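This account rests on a few compounds, and the source may have more. Where it says the series, first, only, none or still open, it means among the compounds named here.

Series notes. Compound 1 `COc1cc(C(=O)N2CO[C@](CCN3CCC(n4c(O)nc5ccccc54)CC3)(c3ccc(Cl)c(Cl)c3)C2)cc(OC)c1OC` is the reference point. In an assay on isolated protein for inhibition of Substance-P receptor (Cavia porcellus), tested at 1 ug/mL (on this read-out higher numbers stand for more inhibition at the one concentration tested (going by the name of the read-out) and lower numbers for less inhibition), compound 1 gives 100%, the highest of the two numbers in hand. The other measured member, compound 2 `COc1cc(C(=O)N2CO[C@](CCN3CCC4(CC3)CN(c3ccccc3)C(=O)O4)(c3ccc(Cl)c(Cl)c3)C2)cc(OC)c1OC`, gives 86% in this assay, a number that sits below compound 1 by more than the usual scatter of this kind of measurement.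

Compound 3 `COc1cc(C(=O)N2CO[C@](CCN3CCC(NC(=O)c4ccccc4)CC3)(c3ccc(Cl)c(Cl)c3)C2)cc(OC)c1OC` has not yet been measured in this assay. Relative to compound 1 the change is benzamido in place of 2-hydroxy-1H-benzimidazol-1-yl on a saturated ring carbon. Among the measured compounds shown here, no measured pair isolates this change, so its effect is not known from the data in hand.

Compound 1 already stands at the top of the observed range, and compound 2 at 86% shows that a different large group on the saturated ring carbon can come in lower. On that basis a modest downward step is expected, and the step is estimated at a number 12 percentage points lower from compound 1 to compound 3 (beyond the scatter). Compound 3 is expected to give about 88% in this assay, with a plausible range from 65% to 100%.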

Compound 3, a percentage reported as inhibition, at one concentration (the size of the read-out at that concentration, not a potency): 89%
For compound 3 the middle estimate is 1 percentage points below the measured one, within the range that was stated.
By their numbers in this assay, from the lowest: compounds 2 and 3 (each within the scatter of the next); then compound 1.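

This position now has its first step read from a single change: in this assay, benzamido in place of 2-hydroxy-1H-benzimidazol-1-yl on the saturated ring carbon gives a number 11 percentage points lower from compound 1 to compound 3 (beyond the scatter). The step is modest, and the inhibition that remains shows that the five-membered aromatic ring with 2 hetero atoms is not needed for substantial inhibition at this one concentration, although its removal, together with the other changes in this swap, does cost inhibition beyond the scatter. Nothing in hand explains the step or separates the contribution of the lost ring from that of the new carbonyl and amide hydrogen.

Still open, from the compounds shown here alone, is whether the amide link or the phenyl ring of benzamido carries the inhibition that remains, a question that a plain amine, a phenylacetamido group with its longer chain or a carboxylic acid on the same saturated ring carbon would help to address. Also open, going by these compounds, is how these percentages at a single concentration relate to potency, since a percentage of this kind does not give one.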